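Halogen Swaps on the Aryl Group of a Shared Core

The source may report more compounds than this note shows. Statements on the series, on what has been measured and on what is new or still open speak of the compounds shown alone.

Compound 1 `O=C(Nc1ccc(Oc2ccnc3[nH]ccc23)cc1)c1cn(-c2ccc(Cl)cc2)c2ccccc2c1=O` and compound 2 `O=C(Nc1ccc(Oc2ccnc3[nH]ccc23)cc1)c1cn(-c2ccc(Br)cc2)c2ccccc2c1=O` share one core and differ only in the group on the aromatic nitrogen. In a functional assay on HepG2 cells (Homo sapiens) for inhibition, read by MTT assay, with a stated time of 72 h (on this read-out higher numbers stand for weaker inhibition and lower numbers for stronger inhibition), compound 1 gives 250 nM, and compound 2 gives 220 nM; the step of a 1.1-fold lower number from compound 1 to compound 2 (0.06 log units; within the scatter) shows that this exchange leaves the read-out unchanged. Compound 3 `O=C(Nc1ccc(Oc2ccnc3[nH]ccc23)cc1)c1cn(-c2ccc(C(F)(F)F)cc2Cl)c2ccccc2c1=O` carries a 2-chloro-4-(trifluoromethyl)phenyl at the same place. In this assay compound 3 has "not determined" (no result reported), so it stands nowhere on the numbers. Compound 4 `O=C(Nc1ccc(Oc2ccnc3[nH]ccc23)cc1)c1cn(-c2ccc(F)c(Cl)c2)c2ccccc2c1=O` differs from compound 3 in one place: 3-chloro-4-fluorophenyl in place of 2-chloro-4-(trifluoromethyl)phenyl on an aromatic nitrogen. For the measured compounds named here, only the step between compound 1 and compound 2 bears on this change, and it was within the scatter, so no step beyond the scatter is expected. Compound 4 is expected to give about 250 nM in this assay, estimated between 100 nM and 700 nM.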

Compound 4, half-maximal inhibitory concentration: 1120 nM
Compound 4: middle estimate off by 4.5-fold (0.65 log units), on the low side; measured number outside the range, above it.
By their numbers in this assay, from the lowest: compounds 2 and 1 (each within the scatter of the next); then compound 4.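

In this assay, the group on the aromatic nitrogen proved able to move the read-out beyond the scatter, which the exchange of chloro for bromo had not shown. The change to 3-chloro-4-fluorophenyl brings a 5.1-fold higher number from compound 2 to compound 4 (0.71 log units; beyond the scatter) and a 4.5-fold higher number from compound 1 to compound 4 (0.65 log units; beyond the scatter). No measurement at hand gives a reason for these steps. The compounds shown leave open whether the chloro or the fluoro of the new group accounts for the higher number, since both differ at once from the earlier groups. They also leave open how an amine or a carboxylic acid on this aryl group would read.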